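This account rests on a few compounds, and the source may have more. Where it says the series, first, only, none or still open, it means among the compounds named here.

For the measured compounds named here, in an ADME assay on liver (Homo sapiens) for metabolic stability, read by LC-MS, using microsomes and NADPH, tested at 1 uM (a lower number here means that the compound disappears faster, a higher number that the compound lasts longer), compound 2 `Cc1ccc(/C=C/C=N/NC(=O)CN2C(=O)N(c3ccc(Cl)cc3)C(N(O)C(=O)Nc3ccc(Cl)cc3)C2(C)C)o1` gives 8.25 h, the higher of the two numbers measured so far; compound 1 `COCCOc1ccc(N2C(=O)N(CC(=O)N/N=C/C=C/c3ccc(C)o3)C(C)(C)C2N(O)C(=O)Nc2ccc(Cl)cc2)cc1` gives 0.53 h. Going by the values given here, the one measured step, a 16-fold higher number from compound 1 to compound 2 (1.19 log units; beyond the scatter), comes from a single swap, chloro in place of 2-methoxyethoxy on an aromatic carbon, and points clearly towards a longer-lasting compound.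

Compound 3 `COCCOc1ccc(NC(=O)N(O)C2N(c3ccc(Cl)cc3)C(=O)N(CC(=O)N/N=C/C=C/c3ccc(C)o3)C2(C)C)cc1` takes the opposite direction, (2-methoxyethoxy in place of chloro on an aromatic carbon). Among the compounds with values here, the change sits on the other aryl ring of the shared core than the one altered between compound 1 and compound 2, so the measured step is only a partial guide. Within the data shown here, still, it is the only evidence available: reintroducing the 2-methoxyethoxy group, which in compound 1 went together with the lower number 0.53 h, is expected to pull the number down again in this assay. The position differs, so the full size of a 16-fold higher number from compound 1 to compound 2 (1.19 log units; beyond the scatter) need not be reached.

The expected step is therefore a 4.1-fold lower number from compound 2 to compound 3 (0.62 log units; beyond the scatter), and compound 3 is estimated at 2 h, with a likely range from 0.5 h to 6 h.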

Compound 3, half-life: 2.07 h
The estimate for compound 3 lay 1.0-fold (0.01 log units) below the measured number, within the range that was stated.
By their numbers in this assay, from the lowest: compound 1; then compound 3; then compound 2.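

In this assay, for the compounds shown here, the earlier compounds showed the effect of this swap on only one of the two aryl rings of the shared core. The new step, a 4.0-fold lower number from compound 2 to compound 3 (0.60 log units; beyond the scatter), shows that putting 2-methoxyethoxy in place of chloro on the other ring, on the (4-chlorophenyl)amino side, also gives a change beyond the usual scatter, in the same direction as the earlier swap read in reverse. This step counts as modest, whereas a 16-fold higher number from compound 1 to compound 2 (1.19 log units; beyond the scatter) counts as large, so among the compounds shown the swap is seen on both rings, but with a different printed size on each, and compound 2, carrying chloro on both rings, keeps the highest number. Nothing available explains the loss of stability on either ring or the difference in size between the two steps.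

Still open, from the compounds shown here alone, is whether a plain methoxy group, a hydroxyl or a longer chain ending in an amine, placed on this same aromatic carbon, would stay close to compound 2 or fall towards compound 3. Also open, going by these compounds, is what 2-methoxyethoxy on both rings at once would give.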